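The source may report more compounds than this note shows. Statements on the series, on what has been measured and on what is new or still open speak of the compounds shown alone.

Compound 1, `N#C[Se]c1ccc(NC(=O)Oc2ccc(F)cc2)cc1`: 41900 nM
Compound 2, `C=CCOC(=O)Nc1ccc([Se]C#N)cc1`: 38100 nM

Both numbers come from a functional assay on CCRF-CEM cells (Homo sapiens) for cytotoxicity, read by MTT assay, with a stated time of 72 h; a lower number here means a stronger inhibitor of growth, a higher number a weaker inhibitor of growth. Compound 1 stands at one end of these two numbers, yet its gap to compound 2 lies within the usual scatter, so no difference between the two can be claimed. Compound 3, `N#C[Se]c1ccc(NC(=O)Oc2ccc(Cl)cc2)cc1`, has not been measured in this assay. It differs from compound 1 in one place: chloro in place of fluoro on an aromatic carbon. Among the compounds with values here, no measured pair shows what this change does here, so only a small step is expected, in either direction, not beyond the scatter. Compound 3 is expected to show a step of a 1.2-fold lower number from compound 1 to compound 3 (0.08 log units; within the scatter). Compound 3 is estimated at 35000 nM, within a range from 15000 nM to 80000 nM.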

Compound 3, concentration for total growth inhibition: 45100 nM
Beside the measured number, compound 3's estimate is 1.3-fold (0.11 log units) below it; the measured number falls inside the stated range.
By their numbers in this assay, from the lowest: compounds 2, 1 and 3 (each within the scatter of the next).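

Within the data shown here, putting chloro in place of fluoro on this aromatic carbon gives the first measured step at this position: in this assay, the change gives a 1.1-fold higher number from compound 1 to compound 3 (0.03 log units; within the scatter). At this position, para to a large group, the two halogens therefore cannot be told apart in this assay. No measurement shown here offers an explanation for this result.

The compounds shown leave open whether a quite different group on the same carbon, such as an amine or a carboxylic acid, would shift the number beyond the scatter from compound 1.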